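This account rests on a few compounds, and the source may have more. Where it says the series, first, only, none or still open, it means among the compounds named here.

Three compounds measured so far in a functional assay on CNE-2 cells (Homo sapiens) for antiproliferative activity, read by sulforhodamine B assay, with a stated time of 48 h; on this read-out lower numbers stand for stronger inhibition and higher numbers for weaker inhibition:
compound 1 `COc1ccc(-c2ccccc2C(=O)/C=C/c2ccc(Br)cc2)cc1OC`: 4800 nM
compound 2 `COc1ccc(C(=O)/C=C/c2ccccc2-c2ccc(F)nc2)cc1`: 13000 nM
compound 3 `COc1ccc(C(=O)/C=C/c2ccccc2-c2ccc(F)nc2)cc1OC`: 17000 nM

Compound 2 sits with compound 3 at the weaker end of this small set. Compound 1 gives 4800 nM as a lower number than compound 2 with 13000 nM as its own. The two neighbours at the weaker end cannot be told apart, since the data show a 1.3-fold higher number from compound 2 to compound 3 (0.12 log units; within the scatter) for the addition of a methoxy group in place of hydrogen on an aromatic carbon.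

The next compound is compound 4 (`O=C(/C=C/c1ccccc1-c1ccc(F)nc1)c1cccc(O)c1`), not yet measured. It makes one change to compound 2: 3-hydroxyphenyl in place of 4-methoxyphenyl on a carbonyl carbon. The group swapped here is the one that took the extra methoxy group in compound 3, so that single step is the closest evidence. Going by the values given here, it is only indirect, as no measured compound carries a hydroxy group, and compound 1 differs from compound 2 in more than one place.

Among the compounds with values here, with a 1.3-fold higher number from compound 2 to compound 3 (0.12 log units; within the scatter) as the only guide, no step beyond the scatter is expected in this assay in either direction. The estimate amounts to a 1.2-fold lower number from compound 2 to compound 4 (0.07 log units; within the scatter) as the expected step. For compound 4 the expected value is 11000 nM with an estimated range from 4000 nM to 30000 nM for a measurement still to come.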

Compound 4, half-maximal inhibitory concentration: 8700 nM
Compound 4: middle estimate off by 1.3-fold (0.10 log units), on the high side; the range from low to high includes it.
By their numbers in this assay, from the lowest: compounds 1, 4, 2 and 3 (each within the scatter of the next, the first and the last beyond it).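

The earlier compounds shown here showed only what happens when a methoxy group is added to this aromatic ring, with a 1.3-fold higher number from compound 2 to compound 3 (0.12 log units; within the scatter) in this assay. Compound 4 tests a larger change on the same carbonyl carbon: 3-hydroxyphenyl replaces 4-methoxyphenyl, which gives a 1.5-fold lower number from compound 2 to compound 4 (0.17 log units; within the scatter) and brings the first hydrogen-bond donor to this group, so even this exchange of the whole aryl group produces no step beyond the scatter. No measured information on these compounds bears on why these two groups give numbers within the scatter of each other.

This single step changes both the kind of oxygen group and its place on the ring, so the contributions of those two differences cannot be separated. The compounds shown also leave open how this assay would respond if an amine or a carboxylic acid stood on this ring, and whether any group at this position can produce a step beyond the scatter from compound 2.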